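Solubility of a Shared Core with Varied Side Chains

This account rests on a few compounds, and the source may have more. Where it says the series, first, only, none or still open, it means among the compounds named here.

Measured compounds:
compound 1, `CN(CCC#N)C[C@H]1CN(c2ccc(-n3cc(-c4ccccn4)cn3)c(F)c2)C(=O)O1`, 64500 nM
compound 2, `CC(=O)OC[C@H]1CN(c2ccc(-n3cc(-c4ccccn4)cn3)c(F)c2)C(=O)O1`, 373000 nM
compound 3, `O=C1O[C@@H](CSc2cccs2)CN1c1ccc(-n2cc(-c3ccccn3)cn2)c(F)c1`, 8500 nM

Three compounds share one core and differ only in the group on a saturated chain carbon bound to a saturated ring carbon. In a physicochemical assay for solubility, read by HPLC, with a stated time of 24 h (a higher number here means a more soluble compound, a lower number a less soluble compound), compound 3 stands lowest of the three numbers: from compound 1 it lies a 7.6-fold lower number from compound 1 to compound 3 (0.88 log units; beyond the scatter), and from compound 2 it lies a 44-fold lower number from compound 2 to compound 3 (1.64 log units; beyond the scatter), both beyond the scatter. Compound 4, `O=CNC[C@H]1CN(c2ccc(-n3cc(-c4ccccn4)cn3)c(F)c2)C(=O)O1`, has not been measured in this assay. It differs from compound 3 as follows: formylamino in place of (thiophen-2-yl)sulfanyl on a saturated chain carbon bound to a saturated ring carbon. Both measured steps that end at compound 3 bear on this change, since each replaces a smaller, more polar group by the (thiophen-2-yl)sulfanyl group and each lowers the number, one modestly and one by a large amount. Going back the other way, with a small group carrying a hydrogen-bond donor entering, a large rise is expected in this assay, on the order of a 35-fold higher number from compound 3 to compound 4 (1.55 log units; beyond the scatter). Compound 4 is therefore estimated at 300000 nM, with a range from 70000 nM to 1200000 nM.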

Compound 4, solubility: 217000 nM
Compound 4: middle estimate off by 1.4-fold (0.14 log units), on the high side, within the range that was stated.
By their numbers in this assay, from the lowest: compound 3; then compound 1; then compounds 4 and 2 (each within the scatter of the next).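

In this assay, formylamino on a saturated chain carbon bound to a saturated ring carbon gives a large rise over (thiophen-2-yl)sulfanyl (a 26-fold higher number from compound 3 to compound 4 (1.41 log units; beyond the scatter)), showing that a group with 3 heavy atoms and no ring can reverse the low number of compound 3. Acetoxy is also no longer the only group at the top of the series, since formylamino cannot be told apart from it (a 1.7-fold lower number from compound 2 to compound 4 (0.24 log units; within the scatter)). Formylamino also stands modestly clear of (2-cyanoethyl)(methyl)amino (a 3.4-fold higher number from compound 1 to compound 4 (0.53 log units; beyond the scatter)), so the (2-cyanoethyl)(methyl)amino group of compound 1 now lies beyond the scatter of two other groups on the high side.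

No measured evidence on these groups is available to explain these steps. On these data alone, whether a primary amine, a carboxylic acid or a longer acylamino chain at this place would give a number as high as formylamino remains open.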